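Swapping bromo for trifluoromethyl on a thiourea aryl ring

The compounds below may be only part of what the source reports. "The series", "measured", "known", "first", "only" and "open" are said of these compounds alone.

Three thienopyridine thioureas have been measured in a functional assay on MKN-74 cells (Homo sapiens) for antiproliferative activity, with a stated time of 24 h; a lower number here means a stronger inhibitor, a higher number a weaker inhibitor. Compound 1 `NC(=O)c1c(NC(=O)c2ccccc2Cl)sc2c1CCN(C(=S)Nc1ccccc1Br)C2` gives 10800 nM, compound 2 `NC(=O)c1c(NC(=O)c2ccccc2Cl)sc2c1CCN(C(=S)Nc1ccccc1C(F)(F)F)C2` gives 1870 nM, and compound 3 `NC(=O)c1c(NC(=O)c2ccccc2Br)sc2c1CCN(C(=S)Nc1ccccc1Br)C2` gives 13700 nM. The change trifluoromethyl in place of bromo on an aromatic carbon produced a 5.8-fold lower number from compound 1 to compound 2 (0.76 log units; beyond the scatter). Compound 3 differs from compound 1 in its core by bromo in place of chloro on an aromatic carbon, and this gave a 1.3-fold higher number from compound 1 to compound 3 (0.10 log units; within the scatter). Compound 4 `NC(=O)c1c(NC(=O)c2ccccc2Br)sc2c1CCN(C(=S)Nc1ccccc1C(F)(F)F)C2` is not yet measured; it differs from compound 3 by trifluoromethyl in place of bromo on an aromatic carbon, the same change as that from compound 1 to compound 2, made on the core of compound 3. Because a 5.8-fold lower number from compound 1 to compound 2 (0.76 log units; beyond the scatter), a step of comparable size is expected for compound 4, a 5.5-fold lower number from compound 3 to compound 4 (0.74 log units; beyond the scatter). Compound 4 is therefore estimated at 2500 nM in this assay, with a likely range of 1000 nM to 6500 nM.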

Compound 4, half-maximal inhibitory concentration: 24300 nM
Estimate against measurement, compound 4: 9.7-fold (0.99 log units) below; the whole stated range lies below it.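

In this assay, trifluoromethyl in place of bromo gives a 1.8-fold higher number from compound 3 to compound 4 (0.25 log units; within the scatter), so the gain seen on the core of compound 1 does not carry over to the core of compound 3: the same change on two cores in this assay, a 5.8-fold lower number (0.76 log units; beyond the scatter) from compound 1 to compound 2 and a 1.8-fold higher number (0.25 log units; within the scatter) from compound 3 to compound 4, 10-fold (1.01 log units) apart, beyond the scatter of two such steps Bromo in place of chloro likewise depends on its partner group, giving a 13-fold higher number from compound 2 to compound 4 (1.11 log units; beyond the scatter) when trifluoromethyl is present: the same change on two cores in this assay, a 1.3-fold higher number (0.10 log units; within the scatter) from compound 1 to compound 3 and a 13-fold higher number (1.11 log units; beyond the scatter) from compound 2 to compound 4, 10-fold (1.01 log units) apart, beyond the scatter of two such steps These four compounds show that the two changes do not act independently here, but they do not show why, nor whether this holds beyond the series shown.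

From the compounds shown here alone, it remains open whether the combination of chloro and trifluoromethyl in compound 2 is a singular case. Going by these compounds, whether the same dependence appears with fluoro, methyl or methoxy on either aryl ring also remains open.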